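A few compounds are considered here, and "the series" means these few. Any claim that something is new, unique, unknown or untested is made for them only; others in the source may bear on it.

In a functional assay on DU-145 cells (Homo sapiens) for cytotoxicity, read by ELISA, with a stated time of 4 days (on this read-out lower numbers stand for stronger inhibition and higher numbers for weaker inhibition), compound 1 (`Cc1ccsc1-c1cc(-c2ccc(Cl)o2)cc(-c2ccco2)n1`) gives 27300 nM and compound 2 (`Cc1ccsc1-c1cc(-c2ccc(Cl)o2)cc(-c2cccc(Cl)c2)n1`) gives 20500 nM while compound 3 (`Cc1ccsc1-c1cc(-c2ccc(Cl)o2)cc(-c2ccc(Cl)cc2)n1`) gives 21900 nM in the same read-out. Compound 3 therefore cannot be told apart from the other two, since all three numbers lie within the usual scatter of one another.

Compound 4 (`Cc1ccsc1-c1cc(-c2ccc(Cl)o2)cc(-c2cccnc2)n1`) changes the group that already varies across these three compounds. It carries pyridin-3-yl in place of 4-chlorophenyl on an aromatic carbon, and the counted difference is pyridin-3-yl in place of 4-chlorophenyl on an aromatic carbon in this swap.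

Within the data shown here, three measured steps bear on it: a 1.3-fold lower number from compound 1 to compound 2 (0.12 log units; within the scatter) and a 1.2-fold lower number from compound 1 to compound 3 (0.10 log units; within the scatter) and a 1.1-fold higher number from compound 2 to compound 3 (0.03 log units; within the scatter) in turn. Each stays small, so exchanging this group has not yet moved the number measurably. Among the measured compounds shown here, no measured compound carries pyridin-3-yl, however, which leaves the expectation uncertain. In this assay no step beyond the scatter is expected, in either direction.

The estimated step is a 1.0-fold higher number from compound 3 to compound 4 (0.00 log units; within the scatter) in this case. For compound 4 the expected value is 22000 nM with an estimated range from 10000 nM to 45000 nM here.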

Compound 4, half-maximal inhibitory concentration: 30800 nM
For compound 4 the middle estimate is 1.4-fold (0.15 log units) below the measured one; the range from low to high includes it.
By their numbers in this assay, from the lowest: compounds 2, 3, 1 and 4 (each within the scatter of the next).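

Replacing the carbon-only ring of 4-chlorophenyl with pyridin-3-yl adds a ring nitrogen and a hydrogen-bond acceptor and removes the chlorine, yet in this assay the result is only (a 1.4-fold higher number from compound 3 to compound 4 (0.15 log units; within the scatter)). The comparisons with the other two compounds give the same picture (a 1.5-fold higher number from compound 2 to compound 4 (0.18 log units; within the scatter); a 1.1-fold higher number from compound 1 to compound 4 (0.05 log units; within the scatter)). This position next to the ring nitrogen has therefore now held four different aromatic rings, including one with a ring nitrogen, without any step beyond the scatter, and nothing measured independently of this read-out helps interpret these numbers.

Going by these compounds, it remains open whether a non-aromatic group at this position, such as an amine, a carboxylic acid or a longer alkyl chain, would move the number beyond the scatter. The compounds shown also leave open what changing the 3-methylthiophen-2-yl or 5-chlorofuran-2-yl group would do, since both stay the same throughout.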